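This account rests on a few compounds, and the source may have more. Where it says the series, first, only, none or still open, it means among the compounds named here.

Measured compounds:
compound 1 `O=C(Nc1cccc(-c2cccc(F)c2)c1)C(Cl)Cl` — > 50000 nM
compound 2 `O=C(Nc1cccc(-c2ccccc2Cl)c1)C(Cl)Cl` — > 50000 nM

Compound 1 `O=C(Nc1cccc(-c2cccc(F)c2)c1)C(Cl)Cl` carries a fluoro group on its outer ring. In a functional assay on NCI-H460 cells (Homo sapiens) for cytotoxicity, read by MTT assay, with a stated time of 68 h (on this read-out lower numbers stand for stronger inhibition and higher numbers for weaker inhibition), compound 1 gives > 50000 nM, which is a limit of the assay and not a number. Compound 2 `O=C(Nc1cccc(-c2ccccc2Cl)c1)C(Cl)Cl` gives > 50000 nM in this assay, again a limit. Both shown values sit at the limit of > 50000 nM in this assay, at which 2 of the 2 values shown sit, so compound 1 does not stand on any measured scale; it is simply not measurably active, and neither value can be set in order against the other. No step between measured compounds is shown.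

Compound 3 `O=C(Nc1cccc(-c2cccc(Cl)c2)c1)C(Cl)Cl` differs from compound 1 by chloro in place of fluoro on an aromatic carbon. Going by the values given here, with no measured step to lean on, the step of a number no higher from compound 1 to compound 3 (the limit leaves the size open) is expected to be none beyond the scatter in this assay. Compound 3 is therefore estimated at 50000 nM, between 20000 nM and 120000 nM, and is expected most likely to be reported only as a limit.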

Compound 3, half-maximal inhibitory concentration: > 50000 nM
Compound 3 gave a limit, no number (the forecaster's own chance of this, stated with the estimate: 80%); the middle value lies on the limit itself.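

Going by these compounds alone, compound 3, like compound 1, gives only a limit, and no step from compound 1 to compound 3 can be read: the limit of > 50000 nM in this assay, at which 3 of the 3 values shown sit. The compounds shown leave open how they rank against one another in this assay, and whether any substituent on the outer ring gives a measurable value there.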